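A few compounds are considered here, and "the series" means these few. Any claim that something is new, unique, unknown or untested is made for them only; others in the source may bear on it.

Compound 1 `Cc1cc(-n2cc(C(=O)Nc3cc(F)cc(F)c3)c(=O)c3ccc(N(C)C)nc32)ccc1OCCCCCCC[N+]1(C)CCCC1` and compound 3 `Cc1cc(-n2cc(C(=O)Nc3cc(F)cc(F)c3)c(=O)c3ccc(N(C)C)nc32)ccc1OCCCCCCC[N+]1(C)CCCCC1` share a core and differ by one change, (a group of 7 heavy atoms (6 carbon, 1 nitrogen; one six-membered non-aromatic ring with 1 hetero atom) in place of a group of 6 heavy atoms (5 carbon, 1 nitrogen; one five-membered non-aromatic ring with 1 hetero atom), on a saturated chain carbon, seven bonds along the chain from an oxygen on an aromatic ring). In an assay on LX2 cells for inhibition of COL1A1 promoter (Homo sapiens), read by a luciferase reporter, with a stated time of 24 h, tested at 20 uM (a lower number here means a weaker effect, a higher number a stronger effect of the compound at the concentration tested), compound 1 gives 26.1%, and compound 3 gives 33%, so that a number 6.9 percentage points higher from compound 1 to compound 3 (within the scatter). Compound 2 `Cc1cc(OCCCCCCC[N+]2(C)CCCC2)cc(-n2cc(C(=O)Nc3cc(F)cc(F)c3)c(=O)c3ccc(N(C)C)nc32)c1` is built from the same atoms joined differently; the difference between the two cores is not broken down here. In this assay compound 2 gives 4.32%, the lowest of the three numbers, with compound 1 the nearest above it beyond the scatter. Compound 4 `Cc1cc(OCCCCCCC[N+]2(C)CCCCC2)cc(-n2cc(C(=O)Nc3cc(F)cc(F)c3)c(=O)c3ccc(N(C)C)nc32)c1` is not yet measured and carries the same change relative to compound 2, (a group of 7 heavy atoms (6 carbon, 1 nitrogen; one six-membered non-aromatic ring with 1 hetero atom) in place of a group of 6 heavy atoms (5 carbon, 1 nitrogen; one five-membered non-aromatic ring with 1 hetero atom), on a saturated chain carbon, seven bonds along the chain from an oxygen on an aromatic ring). Because the step of a number 6.9 percentage points higher from compound 1 to compound 3 (within the scatter) is within the scatter, he expects a step of similar size, a number 5.7 percentage points higher from compound 2 to compound 4 (within the scatter). His estimate for compound 4 in this assay is 10%, between 0% and 25%.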

Compound 4, a percentage reported as inhibition, at one concentration (the size of the read-out at that concentration, not a potency): 46.8%
Beside the measured number, compound 4's estimate is 36.8 percentage points below it; measured number outside the range, above it.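

Set on the core of compound 2, the six-membered non-aromatic ring in place of the five-membered one gives, in this assay, a number 42.5 percentage points higher from compound 2 to compound 4 (beyond the scatter). Carried from one core to the other, the change did not keep the size of its step: the same change on two cores in this assay, a number 6.9 percentage points higher (within the scatter) from compound 1 to compound 3 and a number 42.5 percentage points higher (beyond the scatter) from compound 2 to compound 4, 35.6 percentage points apart, beyond the scatter of two such steps

This shows that, for these two pairs, the step seen on one core was a poor guide to the step on the other, but it does not show why the cores differ, and two pairs give no rule for any further core. The compounds shown leave open whether the same gap between the cores would appear with a morpholine ring or a trimethylammonium group at the chain end. They also leave open how a shorter or longer chain would behave on either core.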